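The compounds below may be only part of what the source reports. "The series", "measured", "known", "first", "only" and "open" are said of these compounds alone.

In an ADME assay on MT4 cells (Homo sapiens) for cytotoxicity, read by MTT assay, with a stated time of 4 days (on this read-out lower numbers stand for higher toxicity in this test and higher numbers for lower toxicity in this test), three compounds on a shared core have been tested. Compound 1 `CN(C)c1nc(Cc2c(F)cccc2F)cc(=O)[nH]1` gives > 94000 nM, which is a limit of the assay. Compound 2 `CCN(C)c1nc(Cc2c(F)cccc2F)cc(=O)[nH]1` gives > 89000 nM, also a limit. For the measured compounds named here, compound 3 `CCCN(C)c1nc(Cc2c(F)cccc2F)cc(=O)[nH]1`, at 85000 nM, holds the only actual number among the three. Compound 4 `CCN(CC)c1nc(Cc2c(F)cccc2F)cc(=O)[nH]1` has the same atoms joined differently: diethylamino in place of methyl(propyl)amino on an aromatic carbon. Going by the values given here, three measured steps bear on this change. The step that the two limits leave unreadable from compound 1 to compound 2 cannot be read, while an at least 1.1-fold lower number from compound 1 to compound 3 (0.04 log units; that floor lies within the scatter) and an at least 1.0-fold lower number from compound 2 to compound 3 (0.01 log units; that floor lies within the scatter) have floors within the scatter. With compound 3 at 85000 nM and none of these steps shown beyond the scatter, no step beyond the scatter is expected in this assay. The expected step is a 1.1-fold lower number from compound 3 to compound 4 (0.03 log units; within the scatter). Compound 4 is estimated at 80000 nM, with an expected range of 50000 nM to 110000 nM.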

Compound 4, half-maximal cytotoxic concentration: > 85000 nM
Compound 4: only a limit was reported; the forecaster's own chance of this, stated with the estimate: 65%; middle value at least 1.0-fold (0.02 log units) away from the limit.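

In this assay, diethylamino in place of methyl(propyl)amino gives a number no lower from compound 3 to compound 4 (the limit leaves the size open). Compound 4 gives only a limit: the limit of > 85000 nM in this assay, at which 1 of the 4 values shown sits. The earlier compounds shown here changed only the size of the amino group, whereas this pair shows that rearranging the same atoms on this aromatic carbon brings no lower number, and the steps to compound 4 from compound 1 and compound 2 cannot be read.

On these data alone, how far the true values of the limit compounds lie from these limits remains open. So does whether a longer chain such as dibutylamino, or a piperidine, would give a lower number here.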